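The source may report more compounds than this note shows. Statements on the series, on what has been measured and on what is new or still open speak of the compounds shown alone.

Measured compounds:
compound 1, `O=C(Nc1ccnnc1)c1cc(N2CCCC2)ccc1OCc1ccccc1`: 20 nM
compound 2, `O=C(Nc1cccnc1)c1cc(C(F)(F)F)ccc1OCc1ccccc1`: 12.6 nM
compound 3, `O=C(Nc1cccc(Cl)c1)c1cc(C(F)(F)F)ccc1OCc1ccccc1`: 25.1 nM

All three were tested in an assay on Sf9 cells for inhibition of Leucine-rich repeat serine/threonine-protein kinase 2 (Homo sapiens), read by TR-FRET, with stated times of 30 min and 2 h; a lower number here means a stronger inhibitor, a higher number a weaker inhibitor. Compound 1 gives 20 nM, and on the three numbers it stands second highest: its nearest neighbour is compound 3, a gap within the scatter, and its furthest is compound 2, also a gap within the scatter, so none of the three can be called stronger or weaker than another on this evidence.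

Compound 4, `CN1CC2(CCN(c3ccc(OCc4ccccc4)c(C(=O)Nc4ccnnc4)c3)CC2)C1`, has not yet been measured. It differs from compound 1 in one place: a group of 10 heavy atoms (8 carbon, 2 nitrogen; one four-membered non-aromatic ring with 1 hetero atom, one six-membered non-aromatic ring with 1 hetero atom) in place of a group of 5 heavy atoms (4 carbon, 1 nitrogen; one five-membered non-aromatic ring with 1 hetero atom), on an aromatic carbon.

Among the measured compounds shown here, the only step between measured compounds that differ in a single place is a 2.0-fold higher number from compound 2 to compound 3 (0.30 log units; within the scatter), and it concerns the aryl group on the amide-type nitrogen, not the aromatic carbon that is changed here. For the measured compounds named here, compound 2 and compound 3 carry a trifluoromethyl where compound 1 carries pyrrolidin-1-yl, but they also differ from compound 1 on the amide nitrogen, so they show only that all three numbers lie close together. Nothing measured therefore speaks for a move beyond the scatter in this assay when a larger group enters at this aromatic carbon.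

The expected step is no change at the digits printed from compound 1 to compound 4 (within the scatter), a step of essentially no size. Compound 4 is estimated at 20 nM, with a range from 6 nM to 70 nM.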

Compound 4, half-maximal inhibitory concentration: 63.1 nM
Beside the measured number, compound 4's estimate is 3.2-fold (0.50 log units) below it; the measured number falls inside the stated range.
By their numbers in this assay, from the lowest: compounds 2, 1 and 3 (each within the scatter of the next); then compound 4.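

In this assay, among the compounds shown here, this is the first change at this aromatic carbon that can be read on its own, and it gives a 3.2-fold higher number from compound 1 to compound 4 (0.50 log units; beyond the scatter) in a pair that differs nowhere else. So the position, meta to the (pyridazin-4-yl)carbamoyl group and para to the benzyloxy group, does respond to what sits on it, which the earlier compounds could not show because each of them also differs from compound 1 on the amide nitrogen. The step is modest, however, so a group with two non-aromatic rings, one four-membered and one six-membered, is accepted here in place of pyrrolidin-1-yl at only a limited cost, and nothing measured alongside these compounds explains the higher number.

The compounds shown leave open whether the rise goes with the larger group as a whole or with its second nitrogen, a question that piperidin-1-yl or morpholin-4-yl at the same carbon would help to separate. As far as these compounds go, it also remains open whether the same step would appear with pyridin-3-yl on the amide nitrogen in place of pyridazin-4-yl.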